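The compounds below may be only part of what the source reports. "The series", "measured", "known", "first", "only" and "open" are said of these compounds alone.

Compound 1, `CC(C)n1ncc2c(C(=O)Nc3cccnc3)cc(-c3cccs3)nc21`: > 200000 nM
Compound 2, `CNS(=O)(=O)c1cccc(NC(=O)c2cc(-c3cccs3)nc3c2cnn3C(C)C)c1`: 25000 nM

In an ADME assay on LLC-MK2 cells (Macaca mulatta) for cytotoxicity, read by spectrophotometry and crystal violet staining, with a stated time of 4 days (a lower number here means that less compound is tolerated, a higher number that more compound is tolerated), compound 1 gives only a limit, > 200000 nM, so its true position is not pinned down. That reading is the limit of > 200000 nM in this assay, at which 1 of the 2 values shown sits. Compound 2, which shares the core, gives 25000 nM in this assay, a number rather than a limit. Compound 3, `CC(C)n1ncc2c(C(=O)Nc3ccc(F)c(F)c3)cc(-c3cccs3)nc21`, has not yet been measured in this assay. It differs from compound 1 in one place: 3,4-difluorophenyl in place of pyridin-3-yl on an amide-type nitrogen. Among the measured compounds shown here, no step between two measured compounds isolates this change, so its size in this assay cannot be read off. The account expects a modest move towards less tolerance, possibly no larger than the scatter, with a fair chance that only a limit is reported again. For compound 3 the expected value in this assay is 100000 nM, between 30000 nM and 250000 nM. The step from compound 1 to compound 3 is thus expected to be an at least 2.0-fold lower number from compound 1 to compound 3 (0.30 log units; that floor lies within the scatter).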

Compound 3, half-maximal cytotoxic concentration: > 200000 nM
Compound 3: no number, only a limit; the forecaster's own chance of this, stated with the estimate: 40%; middle value at least 2.0-fold (0.30 log units) away from the limit.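

In this assay compound 3 gives > 200000 nM, a limit and not a number. Among the compounds shown here, compound 1 also stands at a limit, so no step between compound 1 and compound 3 can be read. The compounds shown leave open whether 3,4-difluorophenyl in place of pyridin-3-yl changes tolerance at all: the limit of > 200000 nM in this assay, at which 2 of the 3 values shown sit.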